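Diethylamino in place of cyclobutylamino on the shared core

The source may hold more compounds than are shown below. What is called first, only, known or untested is meant among the compounds shown, and "the series" means these compounds.

In an ADME assay on Vero cells (Chlorocebus sabaeus) for cytotoxicity, read by CellTiter-Glo, with a stated time of 72 h (a lower number here means that less compound is tolerated, a higher number that more compound is tolerated), compound 1 (`CC(C)(C)Nc1n[n+]([O-])c2ccccc2[n+]1[O-]`) gives 8 ug/mL and compound 2 (`[O-][n+]1nc(NC2CCC2)[n+]([O-])c2ccccc21`) gives 8.9 ug/mL, so compound 2 stands level with compound 1. Among the measured compounds shown here, the only measured step, a 1.1-fold higher number from compound 1 to compound 2 (0.05 log units; within the scatter), stays within the scatter. Compound 3 (`CCN(CC)c1n[n+]([O-])c2ccccc2[n+]1[O-]`) has diethylamino in place of cyclobutylamino on an aromatic carbon. For the measured compounds named here, no measured compound lacks the hydrogen-bond donor, so that step bears only loosely on this change. No shift beyond the scatter is expected in this assay, with an expected 1.1-fold lower number from compound 2 to compound 3 (0.05 log units; within the scatter). For compound 3 the estimate is 8 ug/mL, with an expected range of 3.5 ug/mL to 18 ug/mL.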

Compound 3, half-maximal cytotoxic concentration: 12 ug/mL
Compound 3: middle estimate off by 1.5-fold (0.18 log units), on the low side, within the range that was stated.
By their numbers in this assay, from the lowest: compounds 1, 2 and 3 (each within the scatter of the next).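

In this assay, replacing cyclobutylamino with diethylamino on this aromatic carbon removes the hydrogen-bond donor and the ring and gives a 1.3-fold higher number from compound 2 to compound 3 (0.13 log units; within the scatter) in this series, while replacing (tert-butyl)amino gives a 1.5-fold higher number from compound 1 to compound 3 (0.18 log units; within the scatter) at the same place. This position therefore carries a group with 0 hydrogen-bond donors without a shift beyond the scatter, so the donor is not needed to hold the number at this level. Nothing at hand explains this result.

From the compounds shown here alone, whether a carboxylic acid, a morpholine ring or a longer chain at this aromatic carbon would shift the number beyond the scatter remains open.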